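Isoxazole substituent change on a shared aminopyrazolopyrimidine core

A few compounds are considered here, and "the series" means these few. Any claim that something is new, unique, unknown or untested is made for them only; others in the source may bear on it.

Compound 1, `CC(C)n1nc(-c2cc(C(C)(C)C)on2)c2c(N)ncnc21`, in an assay on TT cells for inhibition of proto-oncogene tyrosine-protein kinase receptor Ret variant C634W (Homo sapiens), read by MTT assay, with a stated time of 10 days (a higher number here means a weaker inhibitor of growth, a lower number a stronger inhibitor of growth), gives > 10000 nM, a limit of the assay.
Compound 2, `CC(C)n1nc(-c2cc(-c3ccc(F)cc3)on2)c2c(N)ncnc21`, in this assay gives > 10000 nM, likewise only a limit.

Compound 2 therefore stands at the assay limit, and the limit of > 10000 nM in this assay, at which 2 of the 2 values shown sit, holds. Within the data shown here, the only measured step, a step that the two limits leave unreadable from compound 1 to compound 2, cannot be read in size. Compound 3, `CCc1cc(-c2nn(C(C)C)c3ncnc(N)c23)no1`, differs from compound 2 by ethyl in place of 4-fluorophenyl on an aromatic carbon. Since both measured compounds sit at the limit, no direction can be expected beyond the scatter; compound 3 is expected at 15000 nM, with a range from 3000 nM to 60000 nM, most likely again a limit, with the step that the limit leaves unreadable from compound 2 to compound 3 expected to be negligible.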

Compound 3, concentration for 50% growth inhibition: 2610 nM
Estimate against measurement, compound 3: 5.7-fold (0.76 log units) above, and the stated range ends above it.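

Ethyl on this aromatic carbon, next to the ring oxygen, gives the first readable value in this assay, with an at least 3.8-fold lower number from compound 2 to compound 3 (0.58 log units; beyond the scatter) and with an at least 3.8-fold lower number from compound 1 to compound 3 (0.58 log units; beyond the scatter). The position therefore tolerates a change that brings the number off the limit, whether ethyl replaces 4-fluorophenyl or tert-butyl. As far as these compounds go, the full size of both steps stays unknown, for compound 1 and compound 2 each give only a limit: the limit of > 10000 nM in this assay, at which 2 of the 3 values shown sit.

From the compounds shown here alone, whether a methyl group, a longer chain such as propyl, or an amine here would lower the number further remains open.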